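A Methyl Added to a Ring Carbon of Compound 2

The compounds below may be only part of what the source reports. "The series", "measured", "known", "first", "only" and "open" are said of these compounds alone.

Compound 2 `CC(C)COC(=O)N1CC(=O)Nc2ccccc21` gives 262000 nM in an ADME assay on MT2 cells (Homo sapiens) for cytotoxicity, read by trypan blue exclusion, with a stated time of 4 days (a lower number here means that less compound is tolerated, a higher number that more compound is tolerated), the highest of the two numbers shown. Compound 1 `CCC(=O)N1CC(=O)Nc2ccccc21` gives 98600 nM, and the two are separated by a 2.7-fold higher number from compound 1 to compound 2 (0.42 log units; beyond the scatter). Compound 3 `CC(C)COC(=O)N1c2ccccc2NC(=O)[C@@H]1C` has not yet been measured; it differs from compound 2 by methyl in place of hydrogen on a saturated ring carbon. Among the measured compounds shown here, the single measured step concerns a change on a carbonyl carbon, not on a saturated ring carbon, so nothing measured speaks to this change. No shift beyond the scatter is expected, and for compound 3 the expected step is no change at the digits printed from compound 2 to compound 3 (within the scatter). Compound 3 is estimated at 262000 nM, within 120000 nM to 550000 nM.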

Compound 3, half-maximal cytotoxic concentration: 117000 nM
Compound 3: the middle estimate sits 2.2-fold (0.35 log units) above what was measured; measured number outside the range, below it.
By their numbers in this assay, from the lowest: compounds 1 and 3 (each within the scatter of the next); then compound 2.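

In this assay, methyl in place of hydrogen on this saturated ring carbon gives a 2.2-fold lower number from compound 2 to compound 3 (0.35 log units; beyond the scatter). This shows that the ring carbon matters as well as the carbonyl carbon: adding a single methyl here is enough to lower the tolerated concentration by a modest step. Nothing available explains why the number falls. Still open, from the compounds shown here alone, is whether a longer chain such as ethyl, or an amine, on this same carbon would lower the number further or raise it, and whether the mirror-image form of the methyl compound would behave alike.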